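Dimethylpiperidine change from compound 2 to compound 4

A few compounds are considered here, and "the series" means these few. Any claim that something is new, unique, unknown or untested is made for them only; others in the source may bear on it.

Values in a physicochemical assay for solubility, in phosphate buffer, measured as kinetic solubility, at pH 7.4; on this read-out lower numbers stand for lower solubility and higher numbers for higher solubility:
- compound 1 `Cc1oc(-c2ccc(Cl)cc2)nc1CN1CCC(C(=O)NCCCN2C[C@H](C)C[C@H](C)C2)CC1` gives > 72 ug/mL (a limit)
- compound 2 `Cc1ccccc1-c1nc(CN2CCC(C(=O)NCCCN3[C@H](C)CCC[C@@H]3C)CC2)c(C)o1` gives > 69 ug/mL (a limit)
- compound 3 `Cc1oc(-c2c(Br)cccc2Br)nc1CN1CCC(C(=O)NCCCN2C[C@H](C)C[C@H](C)C2)CC1` gives 62.4 ug/mL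

Compound 2 gives > 69 ug/mL, which is a limit of this assay and not a number. The next compound is compound 4 `Cc1ccccc1-c1nc(CN2CCC(C(=O)NCCCCN3C[C@H](C)C[C@H](C)C3)CC2)c(C)o1`, and the change from compound 2 is (3,5-dimethylpiperidin-1-yl)methyl in place of 2,6-dimethylpiperidin-1-yl on a saturated chain carbon, three bonds along the chain from an amide-type nitrogen. In words, (3,5-dimethylpiperidin-1-yl)methyl stands in place of 2,6-dimethylpiperidin-1-yl on a saturated chain carbon, three bonds along the chain from an amide-type nitrogen.

Within the data shown here, no measured step covers this change. Among the measured compounds shown here, the only step available, an at least 1.1-fold lower number from compound 1 to compound 3 (0.06 log units; that floor lies within the scatter), lies at another place, on an aromatic carbon, and gives indirect support at most. Compound 3 also carries 3,5-dimethylpiperidin-1-yl and gives 62.4 ug/mL, so a number rather than a limit remains possible in this series. With so little evidence, the expected change is none beyond the scatter, and no direction is expected: an at least 1.0-fold lower number from compound 2 to compound 4 (0.03 log units; that floor lies within the scatter). For compound 4 the estimate is 63 ug/mL, with an expected range of 35 ug/mL to 75 ug/mL.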

Compound 4, solubility: > 71 ug/mL
Compound 4 was reported as a limit; the forecaster's own chance of this, stated with the estimate: 60%; middle value at least 1.1-fold (0.05 log units) from the limit.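

No step can be read from compound 2 to compound 4: in this assay both results are limits and not numbers. The compounds shown leave open whether (3,5-dimethylpiperidin-1-yl)methyl in place of 2,6-dimethylpiperidin-1-yl changes the solubility read-out at all, and if it does, in which direction and by how much.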